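Shifting the methoxy group on the benzyl ether

The compounds below may be only part of what the source reports. "The series", "measured", "known", "first", "only" and "open" are said of these compounds alone.

Both measured compounds sit at the floor of an assay for inhibition of steroid 17-alpha-hydroxylase/17,20 lyase (Homo sapiens), read by HPLC, with a stated time of 5 min, tested at 2.5 uM, in the presence of a further agent that is not named here; a higher number here means more inhibition at the concentration tested (going by the name of the read-out), a lower number less inhibition. Compound 1 `O=c1cc(Cn2ccnc2)c2ccc(OCc3cccc(C(F)(F)F)c3)cc2o1` gives 0% in this assay. Compound 2 `COc1ccc(COc2ccc3c(Cn4ccnc4)cc(=O)oc3c2)cc1` gives 1% in this assay; its number is nominally the higher of the two shown, but the gap to compound 1 lies within the scatter, so the two cannot be ordered and neither shows meaningful inhibition at the concentration tested.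

Compound 3 `COc1cccc(COc2ccc3c(Cn4ccnc4)cc(=O)oc3c2)c1` has the same atoms as compound 2, joined differently: 3-methoxyphenyl in place of 4-methoxyphenyl on a saturated chain carbon bound to an oxygen on an aromatic ring. Among the compounds with values here, no step between measured compounds exists, so there is no measured precedent for moving the methoxy group.

Because compound 1 gives 0% and compound 2 gives 1% in this assay, the change is expected to produce no step beyond the scatter. The step expected in this assay is a number 1 percentage points higher from compound 2 to compound 3 (within the scatter). Compound 3 is accordingly estimated at 2% in this assay, with a range from 0% to 12%.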

Compound 3, a percentage reported as inhibition, at one concentration (the size of the read-out at that concentration, not a potency): 2%
Compound 3: the middle estimate sits on the measured number at the digits printed, and the stated range covers the measured number.
By their numbers in this assay, from the lowest: compounds 1, 2 and 3 (each within the scatter of the next).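

In this assay the exchange of 4-methoxyphenyl for 3-methoxyphenyl on a saturated chain carbon bound to an oxygen on an aromatic ring gives the first measured move of the methoxy group (a number 1 percentage points higher from compound 2 to compound 3 (within the scatter)), and this position shows no response to that move that can be told apart from the scatter. Methoxy in place of trifluoromethyl on an aromatic carbon can now be read as well (a number 2 percentage points higher from compound 1 to compound 3 (within the scatter)), and that exchange also leaves the compounds at the floor of the read-out at the concentration tested, so neither of the two changes separates any pair in the series. Nothing at hand bears on why these compounds stay at the floor.

On these data alone, it remains open whether an amine, a carboxylic acid or a longer chain in place of the substituted benzyl group would bring a number clear of the scatter. It also remains open whether the shared core can give meaningful inhibition in this assay with any group at this position, since all the compounds shown stay within the scatter of one another.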